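Chloro for Fluoro on the Outer Ring of Compound 2

A few compounds are considered here, and "the series" means these few. Any claim that something is new, unique, unknown or untested is made for them only; others in the source may bear on it.

Three compounds measured in a functional assay, read by spectrophotometry, with a stated time of 15 min, tested at 100 ug/mL (a lower number here means a weaker effect, a higher number a stronger effect of the compound at the concentration tested), share one core and differ in the groups at either end. Compound 1, `COC(=O)c1cc(-c2csc(N/N=C/c3cccs3)n2)ccc1OCc1ccccc1`, gives 96.3%. Compound 3, `Clc1ccc(-c2csc(N/N=C/c3cccs3)n2)cc1`, gives 97%. Compound 2, `Fc1ccc(-c2csc(N/N=C/c3ccc(Cl)cc3Cl)n2)cc1`, gives 96%, a reading that stands with the other two inside the usual scatter, its gap to compound 1 and its gap to compound 3 each too small to mean a real difference. Going by the values given here, no two of these measured compounds differ in only one place, so no single structural step between measured compounds can be read off.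

Compound 4, `Clc1ccc(-c2csc(N/N=C/c3ccc(Cl)cc3Cl)n2)cc1`, is not yet measured. It stands to compound 2 as chloro in place of fluoro on an aromatic carbon. Among the compounds with values here, the only guidance is that compounds 1, 2 and 3, carrying different groups at both ends, all give readings close to complete inhibition in this assay. On that basis a step of no size beyond the scatter is expected, in neither direction in particular, and no change at the digits printed from compound 2 to compound 4 (within the scatter) expresses this expectation. Compound 4 is therefore estimated at 96%, with a range from 88% to 99%.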

Compound 4, a percentage reported as inhibition, at one concentration (the size of the read-out at that concentration, not a potency): 92.4%
Compound 4: the middle estimate sits 3.6 percentage points above what was measured; measured number inside the range.
By their numbers in this assay, from the lowest: compounds 4, 2, 1 and 3 (each within the scatter of the next).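

Going by these compounds alone, this is the first comparison in the set between compounds that differ in one place. With the rest of compound 2 held constant, chloro in place of fluoro on an aromatic carbon, para to a large group, gives in this assay a number 3.6 percentage points lower from compound 2 to compound 4 (within the scatter), so the two halogens cannot be told apart at this position at the concentration tested. Nothing in the data shown accounts for this reading or links it to any property of either group.

Within the data shown here, the comparison covers only two halogens and only one group at the far end of the molecule, so it remains open whether the same exchange would read the same with the other end carried by compound 3. Going by these compounds, it also remains open what an amine, a carboxylic acid or a longer alkyl chain on that aromatic carbon would give, and whether any such group would produce a step beyond the scatter in this assay.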